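A few compounds are considered here, and "the series" means these few. Any claim that something is new, unique, unknown or untested is made for them only; others in the source may bear on it.

Three compounds sharing one core differ only in the group carried on an aromatic carbon next to the piperazine nitrogen. Compound 1 `CCCc1ccccc1N1CCN(CCCCCC(=O)NC2CCCc3ccccc32)CC1` gives 49.6 nM in an assay on HEK293 cells for displacement of a labelled ligand from 5-hydroxytryptamine receptor 7 (Rattus norvegicus); on this read-out lower numbers stand for stronger inhibition and higher numbers for weaker inhibition. Compound 2 `CCCCc1ccccc1N1CCN(CCCCCC(=O)NC2CCCc3ccccc32)CC1` gives 2810 nM, and compound 3 `CC(C)(C)c1ccccc1N1CCN(CCCCCC(=O)NC2CCCc3ccccc32)CC1` gives 538 nM. Compound 3 thus stands second highest of the three numbers: the step of an 11-fold higher number from compound 1 to compound 3 (1.04 log units; beyond the scatter) is a large loss, while the step of a 5.2-fold lower number from compound 2 to compound 3 (0.72 log units; beyond the scatter) is a modest gain, and the step of a 57-fold higher number from compound 1 to compound 2 (1.75 log units; beyond the scatter) is the largest movement seen.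

Compound 4 `O=C(CCCCCN1CCN(c2ccccc2-c2ccccc2)CC1)NC1CCCc2ccccc21` has not yet been measured in this assay. It differs from compound 3 in one place: phenyl in place of tert-butyl on an aromatic carbon. Within the data shown here, none of the measured steps exchanges an aromatic ring for a saturated group, so the two steps that end at compound 3, an 11-fold higher number from compound 1 to compound 3 (1.04 log units; beyond the scatter) and a 5.2-fold lower number from compound 2 to compound 3 (0.72 log units; beyond the scatter), show only that the number at this position moves strongly with the shape of the group, in either direction. The direction for a phenyl is therefore uncertain, and a step of moderate size either way is expected, a 1.8-fold lower number from compound 3 to compound 4 (0.25 log units; within the scatter). On that basis compound 4 is estimated at 300 nM, with a range from 50 nM to 2000 nM.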

Compound 4, inhibition constant: 0.13 nM
Beside the measured number, compound 4's estimate is 2300-fold (3.36 log units) above it; measured number below the stated range.
By their numbers in this assay, from the lowest: compound 4; then compound 1; then compound 3; then compound 2.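

In this assay the step of a 4100-fold lower number from compound 3 to compound 4 (3.62 log units; beyond the scatter) is larger than any step among the three saturated groups, and the same holds for the steps of a 380-fold lower number from compound 1 to compound 4 (2.58 log units; beyond the scatter) and a 22000-fold lower number from compound 2 to compound 4 (4.33 log units; beyond the scatter) at this one position. Among the earlier compounds, the lowest number belonged to compound 1 at 49.6 nM and both other groups gave higher numbers, so those compounds showed only that propyl, butyl and tert-butyl are told apart sharply here. Compound 4 adds something new: this position can also give a number far below all three, and it does so with a phenyl, a six-membered aromatic ring of carbon only, in place of a saturated group.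

The compounds shown do not tell whether the gain belongs to the aromatic ring as such or to phenyl alone, which a cyclohexyl, a pyridyl or a phenyl carrying a methoxy or a fluorine on its own ring could begin to separate. Nothing measured here gives a reason for the size of this gain.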